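Replacing the Cyclopropyl Group of Compound 2

The compounds below may be only part of what the source reports. "The series", "measured", "known", "first", "only" and "open" are said of these compounds alone.

In an ADME assay on microsomes from liver (Homo sapiens) for metabolic stability (a lower number here means slower removal, a higher number faster removal of the compound), compound 1 (`CSc1cc(-c2cnc(N)c(OC(F)F)n2)nc(N2C[C@@H]3C[C@H]2CO3)n1`) gives 5.7 mL/min/kg and compound 2 (`Nc1ncc(-c2cc(C3CC3)nc(N3C[C@@H]4C[C@H]3CO4)n2)nc1OC(F)F`) gives 11 mL/min/kg. With only these two measurements, compound 2 stands within the usual scatter of compound 1, so the pair cannot be ranked with confidence.

Compound 3 (`Nc1ncc(-c2cc(N3CC4CC3C4)nc(N3C[C@@H]4C[C@H]3CO4)n2)nc1OC(F)F`) has not yet been measured. It differs from compound 2 at a single place, on an aromatic carbon: a group of 6 heavy atoms (5 carbon, 1 nitrogen; one four-membered non-aromatic ring of carbon only, one five-membered non-aromatic ring with 1 hetero atom) in place of a group of 3 heavy atoms (3 carbon; one three-membered non-aromatic ring of carbon only), on an aromatic carbon. The cyclopropyl group gives way to a larger group that contains a nitrogen and two non-aromatic rings.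

For the measured compounds named here, only one measured step bears on this change. It concerns the same aromatic carbon, where cyclopropyl replaced methylsulfanyl: a 1.9-fold higher number from compound 1 to compound 2 (0.29 log units; within the scatter). Going by the values given here, that step stayed within the scatter, but no measured compound carries the group entering here, so it offers only weak guidance. No change beyond the scatter is therefore expected in this assay, and no direction can be claimed with confidence. The expected change is a 1.1-fold higher number from compound 2 to compound 3 (0.04 log units; within the scatter). For compound 3 the estimated clearance is 12 mL/min/kg, with an expected range from 5 mL/min/kg to 28 mL/min/kg.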

Compound 3, clearance: 9.3 mL/min/kg
Compound 3: middle estimate off by 1.3-fold (0.11 log units), on the high side; the measured number falls inside the stated range.
By their numbers in this assay, from the lowest: compounds 1, 3 and 2 (each within the scatter of the next).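

In this assay, for the compounds shown here, the earlier compounds held only small groups at this place on the six-membered aromatic ring, methylsulfanyl and cyclopropyl, so it was unknown how the read-out would respond to a much larger group with two non-aromatic rings and a nitrogen. That larger group gives a 1.2-fold lower number from compound 2 to compound 3 (0.07 log units; within the scatter) and, set against the methylsulfanyl compound, a 1.6-fold higher number from compound 1 to compound 3 (0.21 log units; within the scatter) so neither step separates it from the smaller groups, and across these three compounds a clear rise in the size of the group at this place comes with no change beyond the scatter. No other measurement is at hand that could account for this result.

From the compounds shown here alone, whether this holds for other kinds of group remains open: a plain dimethylamino group, a morpholine ring or a carboxylic acid at this place might or might not stay within the scatter of these three compounds. Going by these compounds alone, also open is how far the same freedom extends to a longer open chain, since the only group here without a ring is methylsulfanyl.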